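Benzyl for methyl on the selenium of the bis-acyl selenourea

This account rests on a few compounds, and the source may have more. Where it says the series, first, only, none or still open, it means among the compounds named here.

Three measured members of the series share the acyl-isoselenourea or isothiourea motif. Compound 1 `CS/C(=N\C(=O)c1ccco1)NC(=O)c1ccco1` carries sulfur with a methyl group and two furoyl arms; compound 2 `O=C(/N=C(/NC(=O)c1cccs1)[Se]Cc1ccccc1)c1cccs1` carries selenium with a benzyl group and two thiophenecarbonyl arms; compound 3 `C[Se]/C(=N\C(=O)c1cnc2ccccc2c1)NC(=O)c1cnc2ccccc2c1` carries selenium with a methyl group and two quinolinecarbonyl arms. In a functional assay on MCF7 cells (Homo sapiens) for cytotoxicity, read by MTT assay, with a stated time of 72 h (a lower number here means that less compound is tolerated, a higher number that more compound is tolerated), compound 1 reaches only the limit of the assay, reported as > 100000 nM. In this assay compound 2 likewise reaches only the limit, reported as > 100000 nM. Going by the values given here, compound 3 is the sole member with a number in this assay, where compound 3 gives 60700 nM; the other two values sit at the limit of > 100000 nM in this assay, at which 2 of the 3 values shown sit. Compound 1 and compound 2 differ in more than one place, so their two limits say nothing about the benzyl group on its own.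

Compound 4 `O=C(/N=C(/NC(=O)c1cnc2ccccc2c1)[Se]Cc1ccccc1)c1cnc2ccccc2c1` is not yet measured. It differs from compound 3 by phenyl in place of hydrogen on a saturated chain carbon bound to a selenium atom. Among the compounds with values here, no measured step isolates this change. The step of a 1.2-fold higher number from compound 3 to compound 4 (0.06 log units; within the scatter) is expected to stay within the usual scatter, with no clear direction. Compound 4 is therefore estimated at 70000 nM, within 25000 nM to 200000 nM, with a real chance that only a limit is reported.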

Compound 4, concentration lethal to 50% of the cells: > 100000 nM
Compound 4 ended at the assay's limit; the forecaster's own chance of this, stated with the estimate: 45%; at least 1.4-fold (0.15 log units) between middle value and limit.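

In this assay, going by these compounds alone, phenyl in place of hydrogen on a saturated chain carbon bound to a selenium atom gives an at least 1.6-fold higher number from compound 3 to compound 4 (0.21 log units; that floor lies within the scatter) as the first one-place reading at this position. Within the data shown here, that step is only a floor and lies within the scatter, so no direction can be assigned to methyl to benzyl, and the one number remains that of compound 3. The quinolinecarbonyl arms therefore do not yield a number when benzyl sits on the selenium, and compound 4 joins the compounds reported only as a limit: the limit of > 100000 nM in this assay, at which 3 of the 4 values shown sit.

How far beyond the limit compound 4 lies stays open, as does whether methyl to benzyl would read the same with the furoyl or thiophenecarbonyl arms, where neither member shown has a partner differing in one place. Also open, on these data alone, is whether a longer chain on the selenium, an amine on the phenyl group, or sulfur in place of selenium with the quinolinecarbonyl arms kept would give a number inside the range of this assay.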